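Swapping a Fluoro for a Nitro Group on Compound 3

A few compounds are considered here, and "the series" means these few. Any claim that something is new, unique, unknown or untested is made for them only; others in the source may bear on it.

In a functional assay on CCRF-CEM cells (Homo sapiens) for cytotoxicity, in the absence of a further agent (on this read-out higher numbers stand for weaker inhibition and lower numbers for stronger inhibition), compound 3 `CC(C)(C)OC(=O)CCC(Nc1ccc(CN(CCCc2c(N)nc(N)nc2O)c2ccc([N+](=O)[O-])c(F)c2F)cc1)C(=O)OC(C)(C)C` gives 20000 nM, the highest of the three numbers measured. Compound 1 `CC(C)(C)OC(=O)CCC(Nc1ccc(CN(CCCc2c(N)nc(N)nc2O)c2cc(F)cc(F)c2[N+](=O)[O-])cc1)C(=O)OC(C)(C)C` gives 2400 nM and compound 2 `COC(=O)c1ccc(CN(CCCc2c(N)nc(N)nc2O)c2cc(F)c([N+](=O)[O-])cc2[N+](=O)[O-])cc1` gives 4300 nM. For the measured compounds named here, the only single-point step measured, an 8.3-fold higher number from compound 1 to compound 3 (0.92 log units; beyond the scatter), rearranged the fluoro and nitro groups on that ring and raised the number clearly. Compound 4 `CC(C)(C)OC(=O)CCC(Nc1ccc(CN(CCCc2c(N)nc(N)nc2O)c2ccc([N+](=O)[O-])c(F)c2[N+](=O)[O-])cc1)C(=O)OC(C)(C)C` differs from compound 3 in one place: nitro in place of fluoro on an aromatic carbon. Going by the values given here, no measured step makes this exact change, so the direction is uncertain. A modest drop is expected, a 2.0-fold lower number from compound 3 to compound 4 (0.30 log units; within the scatter), because compound 2, which also carries more nitro than fluoro, gives 4300 nM. Compound 4 is therefore estimated at 10000 nM, within a range of 3000 nM to 30000 nM.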

Compound 4, half-maximal inhibitory concentration: 3900 nM
Compound 4: the middle estimate sits 2.6-fold (0.41 log units) above what was measured; measured number inside the range.
By their numbers in this assay, from the lowest: compounds 1, 4 and 2 (each within the scatter of the next); then compound 3.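

In this assay, nitro in place of fluoro on this aromatic carbon, ortho to a fluoro group and meta to a nitro group, gives a 5.1-fold lower number from compound 3 to compound 4 (0.71 log units; beyond the scatter). For the compounds shown here, this is the first step that shows a change of group at this carbon, and the number falls clearly rather than rises when nitro enters. Nothing measured here gives a reason for the drop. On these data alone, whether an amine or a nitrile on this carbon would lower the number in the same way stays open, so the drop cannot yet be tied to nitro alone.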